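The compounds below may be only part of what the source reports. "The series", "measured", "known", "first", "only" and "open" are said of these compounds alone.

Compound 1 `CC[C@@H]1C[C@H](CC)CN(CCCNC(=O)C2CCN(Cc3nc(-c4ccccc4C)oc3C)CC2)C1` and compound 2 `Cc1ccccc1-c1nc(CN2CCC(C(=O)NCCCN3CCC(C)(C)CC3)CC2)c(C)o1` share their core with compound 3 `Cc1oc(-c2c(Br)cccc2Br)nc1CN1CCC(C(=O)NCCCN2C[C@H](C)C[C@H](C)C2)CC1`. In a physicochemical assay for permeability, using PAMPA (on this read-out higher numbers stand for higher permeability and lower numbers for lower permeability), compound 1 gives 1270 10^-6 cm/s. In this assay compound 2 gives 241 10^-6 cm/s, a change of a 5.3-fold lower number from compound 1 to compound 2 (0.72 log units; beyond the scatter). In this assay compound 3 gives < 1 10^-6 cm/s, which is a limit of the assay and not a number. Compound 3 therefore sits at the limit of < 1 10^-6 cm/s in this assay, at which 1 of the 3 values shown sits. Compound 4 `COc1ccc(-c2nc(CN3CCC(C(=O)NCCCN4C[C@H](C)C[C@H](C)C4)CC3)c(C)o2)cc1OC` differs from compound 3 by 3,4-dimethoxyphenyl in place of 2,6-dibromophenyl on an aromatic carbon. Among the compounds with values here, the only measured step concerns the piperidin-1-yl groups, not the aromatic group, so it does not bear on this change. Because compound 3 shows only < 1 10^-6 cm/s, the step of an at least 50-fold higher number from compound 3 to compound 4 (1.69 log units; beyond the scatter) is expected but cannot be sized against a number. Compound 4 is expected to give 50 10^-6 cm/s, between 5 10^-6 cm/s and 400 10^-6 cm/s.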

Compound 4, apparent permeability: 81.9 10^-6 cm/s
Estimate against measurement, compound 4: 1.6-fold (0.21 log units) below; the range from low to high includes it.
By their numbers in this assay, from the lowest: compound 4; then compound 2; then compound 1. At a limit, below all of these: compound 3.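

Replacing 2,6-dibromophenyl with 3,4-dimethoxyphenyl on this aromatic carbon gives an at least 81-fold higher number from compound 3 to compound 4 (1.91 log units; beyond the scatter) in this assay. Within the data shown here, the earlier measured step changed only the piperidin-1-yl group, so this is the first evidence that the read-out also responds to the group at this position. The true size of the step stays unknown, since compound 3 stands at a limit and not a number: the limit of < 1 10^-6 cm/s in this assay, at which 1 of the 4 values shown sits.

Going by these compounds, this single swap removes the bromine atoms and adds the methoxy groups together, so their separate contributions remain unknown. On these data alone, how an unsubstituted phenyl group would read at this position also remains open.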